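The source may hold more compounds than are shown below. What is called first, only, known or untested is meant among the compounds shown, and "the series" means these compounds.

In a functional assay on A549 cells (Homo sapiens) for antiproliferative activity, read by MTT assay, with a stated time of 72 h (a higher number here means a weaker inhibitor, a lower number a stronger inhibitor), compound 1 `O=C(N/N=C/c1ccc(Br)cc1)Nc1ccc(Oc2ccnc3[nH]ccc23)c(F)c1` gives 820 nM, compound 2 `O=C(N/N=C/c1ccc(F)cc1)Nc1ccc(Oc2ccnc3[nH]ccc23)c(F)c1` gives 680 nM, and compound 3 `O=C(N/N=C/c1ccc(Br)cc1)Nc1ccc(Oc2ccnc3[nH]ccc23)cc1` gives 640 nM. Compound 1 and compound 2 differ by fluoro in place of bromo on an aromatic carbon, which made a step of a 1.2-fold lower number from compound 1 to compound 2 (0.08 log units; within the scatter). The core of compound 3 differs from that of compound 1 by hydrogen in place of fluoro on an aromatic carbon, a step of a 1.3-fold lower number from compound 1 to compound 3 (0.11 log units; within the scatter). Compound 4 `O=C(N/N=C/c1ccc(F)cc1)Nc1ccc(Oc2ccnc3[nH]ccc23)cc1` has not yet been measured; it differs from compound 3 by fluoro in place of bromo on an aromatic carbon, the same change that separates compound 1 from compound 2, made at a place described in the same way. Compound 4 is therefore expected to move by a 1.2-fold lower number from compound 3 to compound 4 (0.07 log units; within the scatter) in this assay, because the matching step a 1.2-fold lower number from compound 1 to compound 2 (0.08 log units; within the scatter) stayed within the scatter. For compound 4 the estimate is 550 nM, with a likely range from 300 nM to 1100 nM.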

Compound 4, half-maximal inhibitory concentration: 1430 nM
For compound 4 the middle estimate is 2.6-fold (0.41 log units) below the measured one, and the stated range ends below it.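

Fluoro in place of bromo does not carry over between the two cores in this assay. On the core of compound 3 it gives a 2.2-fold higher number from compound 3 to compound 4 (0.35 log units; beyond the scatter), which does not match the step on the core of compound 1: the same change on two cores in this assay, a 1.2-fold lower number (0.08 log units; within the scatter) from compound 1 to compound 2 and a 2.2-fold higher number (0.35 log units; beyond the scatter) from compound 3 to compound 4, 2.7-fold (0.43 log units) apart, beyond the scatter of two such steps Hydrogen in place of the core's fluoro likewise depends on the other end of the molecule, giving a 2.1-fold higher number from compound 2 to compound 4 (0.32 log units; beyond the scatter) with the 4-fluorophenyl group, unlike its step with the 4-bromophenyl group: the same change on two cores in this assay, a 1.3-fold lower number (0.11 log units; within the scatter) from compound 1 to compound 3 and a 2.1-fold higher number (0.32 log units; beyond the scatter) from compound 2 to compound 4, 2.7-fold (0.43 log units) apart, beyond the scatter of two such steps So, among these four compounds, neither step can be transferred from one core to the other on trust, but both mismatches rest on compound 4, and the numbers do not show why they differ.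

Going by these compounds, it remains open whether a chloro, methyl or methoxy group in place of bromo would follow compound 1 and compound 2 or compound 3 and compound 4. On these data alone, an amine or a carboxylic acid at that place is equally open.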